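A few compounds are considered here, and "the series" means these few. Any claim that something is new, unique, unknown or untested is made for them only; others in the source may bear on it.

Measured so far:
- compound 1, `CN(C(=O)NC(=O)c1cccc([N+](=O)[O-])c1)c1nc(C(F)(F)F)c(C(=O)N/N=C/c2ccccc2C(F)(F)F)s1`: 4.15 ug/mL in a functional assay on HeLa cells (Homo sapiens) for inhibition, read by MTT assay, with a stated time of 72 h; a lower number here means a stronger inhibitor, a higher number a weaker inhibitor
- compound 2, `CNc1nc(C(F)(F)F)c(C(=O)N/N=C/c2ccc(C(F)(F)F)cc2)s1`: > 100 ug/mL

Among the compounds with values here, compound 1 is the only member of the series with a number in this assay. Compound 2 gives > 100 ug/mL, which is a limit of the assay rather than a number. Within the data shown here, of the two values shown, one therefore sits at the limit of > 100 ug/mL in this assay, at which 1 of the 2 values shown sits, so compound 1 stands alone as the reference point and no step between measured compounds can be drawn.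

Compound 3, `CN(C(=O)NC(=O)c1ccc(Cl)cc1Cl)c1nc(C(F)(F)F)c(C(=O)N/N=C/c2ccccc2C(F)(F)F)s1`, is the next member to be measured in this assay. It differs from compound 1 in one place: 2,4-dichlorophenyl in place of 3-nitrophenyl on a carbonyl carbon

Among the measured compounds shown here, with no measured step to lean on, the expectation for compound 3 rests on compound 1 alone. The exchange keeps the rest of the structure of compound 1 intact, and the step expected is a 1.0-fold lower number from compound 1 to compound 3 (0.02 log units; within the scatter), which is to say none beyond the usual scatter. On that basis compound 3 is estimated at 4 ug/mL, with a range from 1.5 ug/mL to 12 ug/mL.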

Compound 3, half-maximal inhibitory concentration: 9 ug/mL
Compound 3: the middle estimate sits 2.3-fold (0.35 log units) below what was measured; measured number inside the range.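

Within the data shown here, on a carbonyl carbon whose other neighbour is an amide-type nitrogen, the exchange of 3-nitrophenyl for 2,4-dichlorophenyl gives the first readable step in this assay: a 2.2-fold higher number from compound 1 to compound 3 (0.34 log units; beyond the scatter), a modest change that lies beyond the usual scatter. This position therefore registers a change of aryl group, yet the two aryl groups shown both leave a measurable number, so the nitro group of compound 1 is not required for a value in this assay. The only limit in the series belongs to a compound that differs from these two in more than one place, and nothing shown accounts for the size of this step.

The exchange replaces the whole substituted ring at once, so the nitro and chlorine contributions cannot be separated, and unsubstituted phenyl, 4-chlorophenyl or a ring carrying an amine or a carboxylic acid would be needed to define this position further. Compound 2 gives > 100 ug/mL in this assay, which is a limit and not a number, and which leaves open what the carbonyl-bearing substituent on the nitrogen contributes as a single change.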